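Extending a Side Chain on a Shared Core

The source may report more compounds than this note shows. Statements on the series, on what has been measured and on what is new or still open speak of the compounds shown alone.

Three compounds have been measured in a functional assay on B16 cells (Mus musculus) for inhibition; a higher number here means a weaker inhibitor, a lower number a stronger inhibitor:

Compound 1, `Cc1ccc(/C=N/NC(N)=S)cc1`: 6800 nM
Compound 2, `CCc1ccc(/C=N/NC(N)=S)cc1`: 3400 nM
Compound 3, `Cc1ccccc1/C=N/NC(N)=S`: 3400 nM

Compound 3 stands level with compound 2 at the digits shown, and the two together hold the lowest numbers of the three in this assay; compound 1 lies apart from compound 3 only by a gap that falls within the scatter. The unmeasured compound 4, `CCc1ccccc1/C=N/NC(N)=S`, differs from compound 3 by methyl in place of hydrogen on a saturated chain carbon bound to an aromatic carbon. Among the measured compounds shown here, one measured step bears directly on this change: a 2.0-fold lower number from compound 1 to compound 2 (0.30 log units; within the scatter), the same methyl for hydrogen on the same kind of carbon, only at another place on the core. That step did not leave the scatter, so for compound 4 the expectation is a step of similar size in this assay, downward if anything, but not beyond the scatter: the estimated step is a 1.5-fold lower number from compound 3 to compound 4 (0.19 log units; within the scatter). Compound 4 is therefore expected at 2200 nM, within a range of 800 nM to 6000 nM.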

Compound 4, half-maximal inhibitory concentration: 2700 nM
The estimate for compound 4 lay 1.2-fold (0.09 log units) below the measured number, and the stated range covers the measured number.
By their numbers in this assay, from the lowest: compounds 4, 2, 3 and 1 (each within the scatter of the next, the first and the last beyond it).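

In this assay methyl in place of hydrogen on a saturated chain carbon bound to an aromatic carbon now has a second reading on a second core, a 1.3-fold lower number from compound 3 to compound 4 (0.10 log units; within the scatter) and so the change no longer rests on a single pair. Neither step leaves the scatter, and the two agree as closely as such steps can be expected to: the same change on two cores in this assay, a 2.0-fold lower number (0.30 log units; within the scatter) from compound 1 to compound 2 and a 1.3-fold lower number (0.10 log units; within the scatter) from compound 3 to compound 4, 1.6-fold (0.20 log units) apart, within the scatter of two such steps. On both cores, then, going from methyl to ethyl at this kind of carbon shifts the number by no more than the scatter, and the compounds shown resolve no difference between the two cores in this change.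

Going by these compounds, whether a longer chain such as propyl, an amine or a carboxylic acid at this carbon would move the number beyond the scatter remains open. Also open, on these data alone, is whether the methyl to ethyl change would read the same on any other core.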